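This account rests on a few compounds, and the source may have more. Where it says the series, first, only, none or still open, it means among the compounds named here.

The series shares one core, carried by compound 1 `COc1ccc(-c2cc(-c3ccc(F)cc3)nc(NC(=O)N/N=C\c3ccc([N+](=O)[O-])cc3)n2)cc1OC`, compound 2 `COc1ccc(-c2cc(-c3ccc(F)cc3)nc(NC(=O)N/N=C\c3cccc(Cl)c3)n2)cc1OC` and compound 3 `C/C(=N/NC(=O)Nc1nc(-c2ccc(C)cc2)cc(-c2ccc(F)cc2)n1)c1ccc(Cl)cc1`. In a functional assay on the whole organism (strain Albino) with Mus musculus as the target, with a stated time of 0.5 h (a higher number here means that more compound is needed for the effect, a lower number that less compound is needed), compound 1 gives 100 mg/kg, compound 2 gives 300 mg/kg and compound 3 gives 30 mg/kg. Compound 2 thus holds the highest number of the three in this assay, with compound 1 nearest and compound 3 furthest. Among the compounds with values here, the single step measured across one change, a 3.0-fold higher number from compound 1 to compound 2 (0.48 log units; beyond the scatter), concerns the group on the carbon with a double bond to nitrogen. Compound 3 differs from compound 2 in more than one place, so that pair shows only its two numbers.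

Compound 4 `COc1ccc(-c2cc(-c3ccc(Cl)cc3)nc(NC(=O)N/N=C\c3cccc(Cl)c3)n2)cc1OC` is the next member. Relative to compound 2 the change is chloro in place of fluoro on an aromatic carbon. Within the data shown here, no measured step touches this ring: the step from compound 1 to compound 2 and the pair of compound 2 with compound 3 leave it unchanged, so there is no precedent of any size for the swap. With nothing pointing either way, the expected step from compound 2 to compound 4 in this assay is no change at the digits printed from compound 2 to compound 4 (within the scatter), none beyond the scatter. Compound 4 is therefore estimated at 300 mg/kg in this assay, with a range from 130 mg/kg to 700 mg/kg.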

Compound 4, dose for half-maximal effect: 100 mg/kg
For compound 4 the middle estimate is 3.0-fold (0.48 log units) above the measured one; measured number below the stated range.
By their numbers in this assay, from the lowest: compound 3; then compounds 1 and 4 (each within the scatter of the next); then compound 2.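

Within the data shown here, the 4-fluorophenyl group, left unchanged by the earlier comparisons, is not a silent part of the series: in this assay, chloro in place of fluoro on this aromatic carbon gives a 3.0-fold lower number from compound 2 to compound 4 (0.48 log units; beyond the scatter), a step beyond the scatter. Among these compounds, this is the first single change read on this ring, para to a large group, and its printed size matches that of the change on the carbon with a double bond to nitrogen, a 3.0-fold higher number from compound 1 to compound 2 (0.48 log units; beyond the scatter), though the two run in opposite directions. No measurement shown here bears on what lies behind the step from fluoro to chloro.

As far as these compounds go, the swap is read only once, with the 3-chlorophenyl group in place, so whether it carries over to the 4-nitrophenyl group of compound 1 or to the other variations in compound 3 remains open. The compounds shown also leave open how the same aromatic carbon would respond to a bromo group, a methoxy group or an amine, and whether the step from fluoro to chloro is part of a wider trend there or stands alone.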